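The source may report more compounds than this note shows. Statements on the series, on what has been measured and on what is new or still open speak of the compounds shown alone.

Measured compounds in a functional assay on HCT-116 cells (Homo sapiens) for inhibition, read by sulforhodamine B assay, with a stated time of 48 h, tested at 50 uM; a higher number here means more inhibition of growth at the concentration tested, a lower number less inhibition of growth:
compound 1, `O=C1C(=O)N(CCCCCn2cc(COc3cc(=O)oc4ccccc34)nn2)c2ccccc21`, 65%
compound 2, `O=C1C(=O)N(CCCCn2cc(COc3cc(=O)oc4ccccc34)nn2)c2ccc(Cl)cc21`, 62%
compound 3, `O=C1C(=O)N(CCCn2cc(COc3cc(=O)oc4ccccc34)nn2)c2ccccc21`, 79%

Compound 2 holds the lowest of the three numbers. Its nearest neighbour is compound 1, whose number lies within the scatter of that of compound 2, so no order between the two can be read. Compound 3 stands furthest from compound 2, and that gap is beyond the scatter.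

Compound 4, `O=C1C(=O)N(CCCCn2cc(COc3cc(=O)oc4ccccc34)nn2)c2ccccc21`, is not yet measured. It differs from compound 2 in one place: hydrogen in place of chloro on an aromatic carbon. The rest of the structure, the four-carbon chain included, is unchanged. For the measured compounds named here, no pair of measured compounds differs in just one place, so no measured step of this kind is known. Compound 1, which also lacks chloro, gives 65% in this assay, and compound 3, likewise without chloro, gives 79%, but both also differ from compound 2 in chain length. The step is expected to be small, upward if anything, and not beyond the scatter. Compound 4 is therefore estimated at 66%, with a range from 52% to 80%. The expected step of a number 4 percentage points higher from compound 2 to compound 4 (within the scatter) stays within the usual scatter.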

Compound 4, percent growth inhibition at one concentration: 72%
Estimate against measurement, compound 4: 6 percentage points below, within the range that was stated.
By their numbers in this assay, from the lowest: compounds 2, 1, 4 and 3 (each within the scatter of the next, the first and the last beyond it).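

In this assay, for the compounds shown here, a single change can now be read on its own for the first time: hydrogen in place of chloro on an aromatic carbon, with the four-carbon chain unchanged, gives a number 10 percentage points higher from compound 2 to compound 4 (within the scatter) for this pair. No order between the two compounds can be read, and the pair gives no sign that chloro at this position is required for growth inhibition at the concentration tested. This reading rests on one pair and applies only to the four-carbon chain.

Going by these compounds, it remains open whether another group on this aromatic carbon, such as fluoro, methoxy or an amine, would give a step beyond the scatter. On these data alone, it also remains open whether the exchange of chloro for hydrogen would give a similar step on a longer chain. Nothing at hand offers an explanation for the size of this step.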